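A Methylphenyl Swap on the Double-Bonded Nitrogen

The source may hold more compounds than are shown below. What is called first, only, known or untested is meant among the compounds shown, and "the series" means these compounds.

Of the compounds shown here, three sharing one core have been measured in a functional assay on HeLa cells (Homo sapiens) for inhibition, read by MTT assay, with a stated time of 48 h; a lower number here means a stronger inhibitor, a higher number a weaker inhibitor. Compound 1 `CCOC(=O)C1=C(N/C=N/c2cccnc2Cl)Nc2[nH]nc(C)c2C1c1ccc(N(C)C)cc1` gives 4630 nM. Compound 2 `CCOC(=O)C1=C(N/N=C(/Br)c2ccccc2)Nc2[nH]nc(C)c2C1c1ccc(N(C)C)cc1` gives 75700 nM. Compound 3 `CCOC(=O)C1=C(N/C=N/c2ccccn2)Nc2[nH]nc(C)c2C1c1ccc(N(C)C)cc1` gives 29200 nM, which puts it in the middle of the three, weaker than compound 1 and stronger than compound 2.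

Compound 4 `CCOC(=O)C1=C(N/C=N/c2ccc(C)cc2)Nc2[nH]nc(C)c2C1c1ccc(N(C)C)cc1` is still unmeasured. It differs from compound 3 by 4-methylphenyl in place of pyridin-2-yl on a double-bonded nitrogen.

The closest evidence is a change at the same place, a modest step of a 6.3-fold higher number from compound 1 to compound 3 (0.80 log units; beyond the scatter), which shows that exchanging the group on this nitrogen can move the number beyond the scatter. The large step of a 16-fold higher number from compound 1 to compound 2 (1.21 log units; beyond the scatter) and the modest step of a 2.6-fold lower number from compound 2 to compound 3 (0.41 log units; beyond the scatter) involve a wider change and bear on it only loosely. Within the data shown here, no measured compound carries 4-methylphenyl, so the data fix no firm direction, and a step of modest size at most is expected in this assay. The expected step is a 1.3-fold lower number from compound 3 to compound 4 (0.12 log units; within the scatter). For compound 4 the estimated value is 22000 nM, with an expected range from 7000 nM to 65000 nM.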

Compound 4, half-maximal inhibitory concentration: 43200 nM
Beside the measured number, compound 4's estimate is 2.0-fold (0.29 log units) below it; the measured number falls inside the stated range.
By their numbers in this assay, from the lowest: compound 1; then compounds 3, 4 and 2 (each within the scatter of the next, the first and the last beyond it).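

In this assay, putting 4-methylphenyl in place of pyridin-2-yl on the double-bonded nitrogen gives a 1.5-fold higher number from compound 3 to compound 4 (0.17 log units; within the scatter), so this exchange of a pyridine ring for a methyl-bearing carbon ring leaves the number within the scatter. The wider change on the amine nitrogen, a 1.8-fold lower number from compound 2 to compound 4 (0.24 log units; within the scatter), also stays within the scatter, whereas the exchange of 2-chloropyridin-3-yl for 4-methylphenyl, a 9.3-fold higher number from compound 1 to compound 4 (0.97 log units; beyond the scatter), lies beyond it; thus, among the three groups now seen on the double-bonded nitrogen, 2-chloropyridin-3-yl alone gives a number set clearly apart from the other two. Nothing in the data at hand gives a reason for these differences.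

The compounds shown leave open whether the chlorine or the pyridine ring of 2-chloropyridin-3-yl goes with the lower number of compound 1, a question that 2-chlorophenyl or pyridin-3-yl on the same nitrogen would help to separate. They also leave open how this assay would respond to a ring carrying an amine or a carboxylic acid at this place.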